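The compounds below may be only part of what the source reports. "The series", "measured", "known", "first", "only" and "open" are said of these compounds alone.

In a functional assay on BXPC-3 cells (Homo sapiens) for inhibition, read by MTT assay, with a stated time of 72 h (a lower number here means that less compound is tolerated, a higher number that more compound is tolerated), compound 1 `CC(C)(Oc1ccc(CCOc2ccc(NC(=O)c3ccccc3)cc2)cc1)C(=O)NS(=O)(=O)c1ccccc1` gives 7000 nM. In this assay compound 2 `CC(C)(Oc1ccc(CCOc2ccc(/N=N/c3ccccc3)cc2)cc1)C(=O)NS(=O)(=O)c1ccc(Cl)cc1` gives > 24000 nM, and this is a limit of the assay, not a number. Compound 2 therefore stands at the limit of > 24000 nM in this assay, at which 1 of the 2 values shown sits, so its true position is not known.

Compound 3 `CC(C)(Oc1ccc(CCOc2ccc(/N=N/c3ccccc3)cc2)cc1)C(=O)NS(=O)(=O)c1ccc([N+](=O)[O-])cc1` keeps all of compound 2 except for one group. It has nitro in place of chloro on an aromatic carbon, para to a large group, which turns the 4-chlorophenyl into a 4-nitrophenyl: nitro in place of chloro on an aromatic carbon.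

Among the compounds with values here, no pair of measured compounds shows what this swap does, so the data offer no direct guide to its size. In this assay no step beyond the usual scatter is expected, and so no direction is predicted either. This expectation rests on the limit for compound 2, > 24000 nM. Written as a move, the estimated change is a number no higher from compound 2 to compound 3 (the limit leaves the size open). The assay may well report only a limit again. For compound 3 the expected value is 24000 nM, with an estimated range from 10000 nM to 50000 nM.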

Compound 3, half-maximal cytotoxic concentration: 17000 nM
Beside the measured number, compound 3's estimate is 1.4-fold (0.15 log units) above it; low and high end bracket the measured number.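

At this place on the aromatic ring, para to a large group, nitro in place of chloro gives this pair its first readable number in this assay: compound 3 gives 17000 nM. Read as a step, this is an at least 1.4-fold lower number from compound 2 to compound 3 (0.14 log units; that floor lies within the scatter), so the swap may do very little or a good deal more, and its true size stays unknown because compound 2 rests on a limit: the limit of > 24000 nM in this assay, at which 1 of the 3 values shown sits. What the result adds is a lower bound on the size of this step and one real value at this place, against which other groups in the same place can be set.

With only chloro and nitro shown here, no trend can be drawn for this place, and what an amine or a methoxy group would do in the same spot remains open. Also open, as far as these compounds go, is whether nitro in place of chloro would give a similar step on a different core, such as the core of compound 1.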